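The source may report more compounds than this note shows. Statements on the series, on what has been measured and on what is new or still open speak of the compounds shown alone.

Measured so far: compound 1 `Nc1ccccc1NC(=O)c1ccc(NC(=S)NCc2cccc(F)c2)cc1`, > 2000 nM; compound 2 `Nc1ccccc1NC(=O)c1ccc(Cn2cc(-c3ccc(NC(=O)NCc4cccnc4)cc3)nn2)cc1`, 18 nM.

In an assay on isolated protein for inhibition of Nicotinamide phosphoribosyltransferase (Homo sapiens), read by fluorescence, with stated times of 5 min and 15 min (a higher number here means a weaker inhibitor, a lower number a stronger inhibitor), compound 1 gives > 2000 nM, which is a limit of the assay and not a number. In this assay compound 2 gives 18 nM. Compound 1 thus stands at the limit of > 2000 nM in this assay, at which 1 of the 2 values shown sits, with no firm number of its own. Compound 3 `Nc1ccccc1NC(=O)c1ccc(NC(=S)NCc2cncc(Br)c2)cc1` differs from compound 1 by 5-bromopyridin-3-yl in place of 3-fluorophenyl on a saturated chain carbon bound to an amide-type nitrogen. Among the compounds with values here, no measured pair covers this change, so no step beyond the scatter is expected in either direction. The expected step is a step that the limit leaves unreadable from compound 1 to compound 3. Compound 3 is expected to give about 3000 nM in this assay, between 1000 nM and 10000 nM.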

Compound 3, half-maximal inhibitory concentration: > 2000 nM
Compound 3 was reported as a limit (the forecaster's own chance of this, stated with the estimate: 70%); the middle value does not contradict the limit.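

For compound 1 and compound 3 no step can be read, as each stands at a limit of the assay and not at a number: the limit of > 2000 nM in this assay, at which 2 of the 3 values shown sit. The compounds shown leave open whether 5-bromopyridin-3-yl in place of 3-fluorophenyl changes the true value in this assay at all.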